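Vero cell cytotoxicity notes on the shared core

The source may report more compounds than this note shows. Statements on the series, on what has been measured and on what is new or still open speak of the compounds shown alone.

Measured compounds:
compound 1 `CCCCOC(=O)Nc1cc2nc(C3CCCCC3)[nH]c2cc1N(C)C` — > 100 ug/mL (a limit)
compound 2 `CCCOCC(=O)Nc1cc2nc(C3CCCCC3)[nH]c2cc1N(C)C` — < 50 ug/mL (a limit)
compound 3 `CN(C)c1cc2[nH]c(C3CCCCC3)nc2cc1NC(=O)c1ccccc1` — > 100 ug/mL (a limit)

In an ADME assay on Vero cells (Chlorocebus sabaeus) for cytotoxicity, read by resazurin assay, with a stated time of 3 days (a lower number here means a stronger inhibitor, a higher number a weaker inhibitor), compound 1 gives > 100 ug/mL, a limit of the assay and not a number. Compound 2 gives < 50 ug/mL, also a limit. Compound 3 gives > 100 ug/mL, again a limit. All three measured steps sit on the carbonyl carbon: an at least 2.0-fold lower number from compound 1 to compound 2 (0.30 log units; that floor lies within the scatter), a step that the two limits leave unreadable from compound 1 to compound 3, an at least 2.0-fold higher number from compound 2 to compound 3 (0.30 log units; that floor lies within the scatter); what can be read is bounded by the limit of < 50 ug/mL in this assay, at which 1 of the 3 values shown sits, and (the limit of > 100 ug/mL in this assay, at which 2 of the 3 values shown sit).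

Compound 4 `CCCCOC(=O)Nc1cc2nc(C3CCCCC3)[nH]c2cc1N(CC)CCN(CC)CC` differs from compound 1 elsewhere: (2-(diethylamino)ethyl)(ethyl)amino in place of dimethylamino on an aromatic carbon. Going by the values given here, no measured step touches that aromatic carbon, and the carbonyl steps give no guidance for it. For compound 4 the expected result is no step beyond the scatter, a number no higher from compound 1 to compound 4 (the limit leaves the size open). Compound 4 is estimated at 100 ug/mL, within 40 ug/mL to 250 ug/mL.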

Compound 4, half-maximal inhibitory concentration: > 50 ug/mL
Compound 4: only a limit was reported (the forecaster's own chance of this, stated with the estimate: 65%); the middle value is on the limit's open side.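

Compound 4 gives > 50 ug/mL, a limit and not a number. Compound 1 also stands at a limit, so no step can be read between compound 1 and compound 4. The compounds shown leave open what size of change, if any, (2-(diethylamino)ethyl)(ethyl)amino brings in place of dimethylamino.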